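Amine aryl swap in a pyrrolidine acid series

The compounds below may be only part of what the source reports. "The series", "measured", "known", "first", "only" and "open" are said of these compounds alone.

Measured so far:
compound 1 `COc1ncc(C(F)(F)F)cc1CN[C@H]1[C@H](C(C)(C)C)[C@@H](C(=O)O)N(C(=O)C2CCCCC2)[C@H]1c1ccccc1`, 85%
compound 2 `CC(C)c1ccccc1[C@H]1[C@@H](Nc2cccnc2N(C)C)[C@H](C(C)(C)C)[C@@H](C(=O)O)N1C(=O)[C@@H]1CCCCO1`, 111%

In an assay on HBE cells for positive allosteric modulation of Cystic fibrosis transmembrane conductance regulator variant F508del (Homo sapiens) (a lower number here means a smaller maximal response, a higher number a larger maximal response), compound 2 gives 111% and stands highest of the two numbers measured; the nearest value, that of compound 1, lies lower by a gap beyond the usual scatter. The two compounds differ in several places at once, so no single step can be read between them.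

Compound 3 `Cc1ccccc1N[C@H]1[C@H](C(C)(C)C)[C@@H](C(=O)O)N(C(=O)[C@@H]2CCCCO2)[C@H]1c1ccccc1C(C)C` is the next member. It differs from compound 2 in one place: 2-methylphenyl in place of 2-(dimethylamino)pyridin-3-yl on an amine nitrogen. The leaving group carries hydrogen-bond acceptors, the entering group carries none; the place on the amine nitrogen, with its saturated ring carbon neighbour, is unchanged.

Among the compounds with values here, no measured step of this kind exists, so the direction is open. A small loss of maximal response in this assay is expected for compound 3, at most modest, possibly within the scatter: a number 13 percentage points lower from compound 2 to compound 3 (beyond the scatter). Compound 3 is estimated at 98%, with a range from 72% to 124%.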

Compound 3, largest response reached (reported as percent of maximum), in percent of the reference or control that the assay uses: 135%
Compound 3: middle estimate off by 37 percentage points, on the low side, outside the stated range (above it).
By their numbers in this assay, from the lowest: compound 1; then compound 2; then compound 3.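

In this assay the series now has its first step that can be read in one place, a number 24 percentage points higher from compound 2 to compound 3 (beyond the scatter), and it shows that 2-(dimethylamino)pyridin-3-yl on the amine nitrogen is not needed for a high maximal response. The 2-methylphenyl group carries no hydrogen-bond acceptors and still gives the larger response, so with the rest of compound 2 held fixed, acceptors on this aryl group are not required. Nothing on hand explains the gain, and no cause can be assigned to it.

On these data alone, the step changes the ring hetero atom and the substituent together, so the share of each in the gain stays open. Also open, as far as these compounds go, is whether a chloro or methoxy group in place of the methyl of 2-methylphenyl would keep this response.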